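From methylcarbamoyl to carbamoyl on the shared core

This account rests on a few compounds, and the source may have more. Where it says the series, first, only, none or still open, it means among the compounds named here.

Within the data shown here, in a functional assay on OVCAR-8 cells (Homo sapiens) for antiproliferative activity (a lower number here means a stronger inhibitor, a higher number a weaker inhibitor), compound 1 `CNC(=O)C[C@@H]1C[C@@H](c2ccc(Cl)c(Cl)c2)[C@H](NC(=O)c2cc(-c3c(Cl)cnn3C)c(Cl)o2)CN1` gives 1130 nM, the highest of the three numbers measured so far. Compound 3 `CC(=O)NCC[C@@H]1C[C@@H](c2ccc(F)c(F)c2)[C@H](NC(=O)c2cc(-c3c(Cl)cnn3C)c(Cl)o2)CN1` gives 880 nM, within the scatter of compound 1. Compound 2 `Cn1ncc(Cl)c1-c1cc(C(=O)N[C@@H]2CNCC[C@H]2c2ccc(C(F)(F)F)cc2)oc1Cl` gives 120 nM, a lower number beyond the scatter of compound 1. Compound 4 `Cn1ncc(Cl)c1-c1cc(C(=O)N[C@@H]2CN[C@H](CC(N)=O)C[C@H]2c2ccc(Cl)c(Cl)c2)oc1Cl` differs from compound 1 in one place: hydrogen in place of methyl on an amide-type nitrogen. Among the measured compounds shown here, no measured pair shows this change, so there is no direct precedent for its size. In this assay, the estimated step of a 1.3-fold lower number from compound 1 to compound 4 (0.10 log units; within the scatter) is expected to stay within the scatter, with no firm direction. Compound 4 is expected at 900 nM, with an estimated range from 350 nM to 2300 nM.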

Compound 4, half-maximal inhibitory concentration: 1000 nM
Compound 4: the middle estimate sits 1.1-fold (0.05 log units) below what was measured; the measured number falls inside the stated range.
By their numbers in this assay, from the lowest: compound 2; then compounds 3, 4 and 1 (each within the scatter of the next).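

Among these compounds, the step of a 1.1-fold lower number from compound 1 to compound 4 (0.05 log units; within the scatter) gives the first direct reading of this change in this assay: hydrogen in place of methyl on the amide-type nitrogen leaves the number within the scatter. On the shared core, then, carbamoylmethyl and (methylcarbamoyl)methyl cannot be told apart in this assay. Nothing shown here bears on the reason for this result. As far as these compounds go, whether an ethyl group or a longer chain on that nitrogen would read the same remains open. So does the effect of a carboxylic acid or an amine in place of the carbamoyl group.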